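Series notes: phenethyl for 4-methylphenyl on the bromoacrylamide scaffold

The compounds below may be only part of what the source reports. "The series", "measured", "known", "first", "only" and "open" are said of these compounds alone.

Three compounds of the series have numbers in a functional assay on L1210 cells (Mus musculus) for inhibition, read by cell counting, with a stated time of 2 days; a higher number here means a weaker inhibitor, a lower number a stronger inhibitor. Compound 1 `C=C(Br)C(=O)Nc1cccc(-c2cn3nc(-c4ccc(C)cc4)sc3n2)c1` gives 920 nM and stands second highest of the three. Compound 3 `C=C(Br)C(=O)Nc1cccc(-c2cn3c(-c4ccc(OC)cc4)csc3n2)c1`, which carries the same bromoacrylamide group on a different core, gives 200 nM, a lower number beyond the scatter. Compound 2 `Nc1cccc(-c2cn3c(-c4ccc(Cl)cc4)csc3n2)c1`, the free aniline, gives 22000 nM, the highest number of the three and far beyond the scatter from compound 1. Within the data shown here, compounds 2 and 3 are not single-change neighbours of compound 1, so their values show only that the bromoacrylamide-bearing compounds sit at the low end and the aniline at the high end.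

The step to compound 4 `C=C(Br)C(=O)Nc1cccc(-c2cn3nc(CCc4ccccc4)sc3n2)c1` concerns the group on the core: phenethyl in place of 4-methylphenyl on an aromatic carbon. No measured pair in the series isolates this kind of change, so the direction of the step is not anchored by any number shown. Given that, the expectation for compound 4 in this assay is a small weakening, near the edge of the scatter, with a step of a 1.6-fold higher number from compound 1 to compound 4 (0.21 log units; within the scatter) from compound 1. Compound 4 is estimated at 1500 nM, with a range from 400 nM to 6000 nM.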

Compound 4, half-maximal inhibitory concentration: 2200 nM
Beside the measured number, compound 4's estimate is 1.5-fold (0.17 log units) below it; low and high end bracket the measured number.
By their numbers in this assay, from the lowest: compound 3; then compound 1; then compound 4; then compound 2.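

In this assay, among these compounds, phenethyl in place of 4-methylphenyl on this aromatic carbon gives a 2.4-fold higher number from compound 1 to compound 4 (0.38 log units; beyond the scatter), the first single-change step. The position therefore responds to this change, but the step is modest, so a group with a flexible chain between the core and its aromatic ring is tolerated here with only a limited loss. The two groups are otherwise alike in what is counted: both are all carbon, each holds one six-membered aromatic ring, and neither has a hydrogen-bond donor or acceptor, while no measurement shown gives a reason for the weakening.

Phenethyl differs from 4-methylphenyl both in the chain and in the loss of the methyl on the ring, and this one step does not separate the two changes. Unsubstituted phenyl, benzyl, or a longer chain ending in an amine at this position would help to separate them, and whether the step carries over to the core of compound 3 also stays open.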